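Swapping Fluoro for Bromo on Compound 3

A few compounds are considered here, and "the series" means these few. Any claim that something is new, unique, unknown or untested is made for them only; others in the source may bear on it.

In a functional assay on HeLa cells (Homo sapiens) for cytotoxicity, read by MTT assay, with a stated time of 24 h (on this read-out higher numbers stand for weaker inhibition and lower numbers for stronger inhibition), compound 1 `COc1ccc(/C=C2\CN(C)C/C(=C\c3ccccc3F)C2=O)cc1OC` gives 14400 nM, compound 2 `CN1C/C(=C\c2cccc([N+](=O)[O-])c2)C(=O)/C(=C/c2ccccc2F)C1` gives 2340 nM and compound 3 `CN1C/C(=C\c2ccc(F)cc2)C(=O)/C(=C/c2cccc([N+](=O)[O-])c2)C1` gives 6250 nM. Compound 3 therefore sits in the middle of the three numbers, with compound 1 higher and compound 2 lower, and both gaps lie beyond the usual scatter of repeated measurements.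

The next compound, compound 4 `CN1C/C(=C\c2ccc(Br)cc2)C(=O)/C(=C/c2cccc([N+](=O)[O-])c2)C1`, has not been measured yet. It differs from compound 3 in a single place: bromo in place of fluoro on an aromatic carbon. Put simply, this turns 4-fluorophenyl into 4-bromophenyl.

Within the data shown here, no measured pair makes this exchange, so the evidence is indirect. Among the measured compounds shown here, the only measured step that touches this group is a 2.7-fold higher number from compound 2 to compound 3 (0.43 log units; beyond the scatter), in which 4-fluorophenyl took the place of 2-fluorophenyl. That modest step shows that a change at this group can move the number, but it reveals nothing about bromo itself. With so little to go on, no step beyond the scatter is expected in this assay, and either direction remains possible. The estimated step is a 1.3-fold lower number from compound 3 to compound 4 (0.10 log units; within the scatter). For compound 4 the expected value is 5000 nM, within an estimated range of 1800 nM to 14000 nM.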

Compound 4, half-maximal inhibitory concentration: 11900 nM
Compound 4: the middle estimate sits 2.4-fold (0.38 log units) below what was measured; the measured number falls inside the stated range.
By their numbers in this assay, from the lowest: compound 2; then compounds 3, 4 and 1 (each within the scatter of the next, the first and the last beyond it).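

Bromo in place of fluoro on this aromatic carbon gives the first direct reading of this exchange in this assay: a 1.9-fold higher number from compound 3 to compound 4 (0.28 log units; within the scatter), so compound 3 and compound 4 cannot be told apart, and swapping these two halogens at this position has no effect that can be distinguished from measurement noise. The comparison with the 2-fluorophenyl compound points the same way for both 4-halophenyl groups, since a 2.7-fold higher number from compound 2 to compound 3 (0.43 log units; beyond the scatter) and a 5.1-fold higher number from compound 2 to compound 4 (0.71 log units; beyond the scatter), both beyond the scatter, so compound 2 keeps the lower number against each of them. Nothing in the data shown explains why the numbers fall as they do.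

The compounds shown leave open how a chloro, a methoxy or an amine on this same aromatic carbon would read, so the tolerance of this position is known only for fluoro and bromo. They also leave open whether the exchange of fluoro for bromo would read the same once the nitrophenyl group elsewhere in the molecule is replaced.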